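Dropping the Distal Aryl Ring: Expected Solubility of Compound 4

A few compounds are considered here, and "the series" means these few. Any claim that something is new, unique, unknown or untested is made for them only; others in the source may bear on it.

Measured compounds:
- Compound 1, `O=[N+]([O-])c1cn2c(n1)OC[C@@H](OCCOc1ccc(-c3ccc(OC(F)(F)F)cc3)cc1)C2`: 0.68 ug/mL
- Compound 2, `O=[N+]([O-])c1cn2c(n1)OC[C@@H](OCC#Cc1ccc(-c3ccc(OC(F)(F)F)cc3)nc1)C2`: 0.72 ug/mL
- Compound 3, `O=[N+]([O-])c1cn2c(n1)OC[C@@H](OCCCc1ccc(OC(F)(F)F)cc1)C2`: 11 ug/mL

Of the compounds shown here, three sharing the same nitro-bearing bicyclic core have been measured in a physicochemical assay for solubility, read by HPLC, at pH 7; on this read-out lower numbers stand for lower solubility and higher numbers for higher solubility. Compound 1 gives 0.68 ug/mL, the lowest of the three numbers. Compound 2 gives 0.72 ug/mL, which lies within the scatter of compound 1, so the two cannot be ordered. Compound 3, the only one of the three that carries a single aromatic ring rather than a biaryl, gives 11 ug/mL, a number that stands beyond the scatter above compound 1.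

Compound 4, `O=[N+]([O-])c1cn2c(n1)OC[C@@H](OCCOc1ccc(OC(F)(F)F)cc1)C2`, has not yet been measured in this assay. It differs from compound 1 in one place: trifluoromethoxy in place of 4-(trifluoromethoxy)phenyl on an aromatic carbon. For the measured compounds named here, no measured pair isolates this exact change, so the expectation rests on the gap between compound 1 and compound 3, where the compound with one aromatic ring shows the much higher number. Compound 4 is therefore expected to rise in this assay, with a step of a 12-fold higher number from compound 1 to compound 4 (1.07 log units; beyond the scatter) that should be well beyond the scatter. For compound 4 the estimate is 8 ug/mL, with a range from 2.5 ug/mL to 25 ug/mL.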

Compound 4, solubility: 50 ug/mL
For compound 4 the middle estimate is 6.3-fold (0.80 log units) below the measured one; the measured number lies above the stated range.
By their numbers in this assay, from the lowest: compounds 1 and 2 (each within the scatter of the next); then compound 3; then compound 4.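

Within the biaryl tail of compound 1, the change at this one place, on an aromatic carbon of a six-membered aromatic ring of carbon only, gives in this assay a 74-fold higher number from compound 1 to compound 4 (1.87 log units; beyond the scatter), a large step beyond the scatter. It is the first step shown between two compounds that differ in one place, and it isolates this exchange of 4-(trifluoromethoxy)phenyl for trifluoromethoxy with the chain and the shared core held the same. The group that leaves is larger by one aromatic ring, while the counts of hydrogen-bond donors, hydrogen-bond acceptors and net charge stay the same on both sides, and nothing available explains why the number moves so far.

The compounds shown leave open whether the step comes from losing the aromatic ring or from the shorter group as such, and whether an amine, a carboxylic acid or a plain fluorine at this place would give a similar number. They also leave open whether the same exchange would give a step of this size on the chains of compound 2 or compound 3.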